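Chain and amide variation on the shared core

The compounds below may be only part of what the source reports. "The series", "measured", "known", "first", "only" and "open" are said of these compounds alone.

Compound 3 `CCc1cc(C(C)=O)c(O)cc1OCCCC(C)(C)C(N)=O` stands highest in an assay on isolated protein for inhibition of leukotriene B4 receptor 1 (Homo sapiens), tested at 10 uM (a lower number here means less inhibition, a higher number more inhibition at the concentration tested (going by the name of the read-out)), where compound 3 gives 92%. In this assay compound 1 `CC(=O)c1cc(C)c(OCCCCC#N)cc1O` gives 79%, and compound 2 `CCc1cc(C(C)=O)c(O)cc1OCCCCCCC(C)(C)C#N` gives 65%, both beyond the scatter below compound 3. Compound 4 `CCc1cc(C(C)=O)c(O)cc1OCCCCCCC(=O)N(C)C` is not yet measured; it differs from compound 3 by 3-(dimethylcarbamoyl)propyl in place of 1-carbamoyl-1-methylethyl on a saturated chain carbon, three bonds along the chain from an oxygen on an aromatic ring. Within the data shown here, the one step that bears on it is a number 27 percentage points higher from compound 2 to compound 3 (beyond the scatter), in which 1-carbamoyl-1-methylethyl replaced 4-cyano-4-methylpentyl. Compound 4 moves part of the way back, since 3-(dimethylcarbamoyl)propyl carries no hydrogen-bond donor, so a drop is expected because compound 2 gave 65%. For compound 4 the expected step is a number 22 percentage points lower from compound 3 to compound 4 (beyond the scatter). Compound 4 is estimated at 70% in this assay, within 50% to 88%.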

Compound 4, a percentage reported as inhibition, at one concentration (the size of the read-out at that concentration, not a potency): 100%
Beside the measured number, compound 4's estimate is 30 percentage points below it, and the stated range ends below it.
By their numbers in this assay, from the lowest: compound 2; then compound 1; then compounds 3 and 4 (each within the scatter of the next).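

At the saturated chain carbon three bonds along the chain from an oxygen on an aromatic ring, 3-(dimethylcarbamoyl)propyl in place of 1-carbamoyl-1-methylethyl gives a number 8 percentage points higher from compound 3 to compound 4 (within the scatter) in this assay, so the change from the primary amide to the dimethyl amide, with no hydrogen-bond donor, leaves no readable difference. Six bonds along the chain, dimethylcarbamoyl in place of 1-cyano-1-methylethyl gives a number 35 percentage points higher from compound 2 to compound 4 (beyond the scatter), which sets this amide end clearly apart from the nitrile end. Nothing at hand gives a cause for either step.

Still open, going by these compounds, is whether a carboxylic acid or an amine at the chain end would hold this level. On these data alone, a longer chain ending in the dimethyl amide is equally open.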